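Methyl Grows to Cyclohexyl on an Aromatic Nitrogen

This account rests on a few compounds, and the source may have more. Where it says the series, first, only, none or still open, it means among the compounds named here.

Compound 1 `CN1C(=S)[C@@H](NC(=O)c2nc(Cc3ccccc3)n(C)n2)COc2ccccc21` is the reference point. Within the data shown here, in a functional assay on HT-29 cells (Homo sapiens) for inhibition, read by luminescence and CellTiter-Glo, with a stated time of 24 h (on this read-out higher numbers stand for an effect only at larger amounts of compound and lower numbers for an effect already at smaller amounts), compound 1 gives 2.5 nM, the lowest of the three numbers measured so far. Compound 2 `CN1C(=S)[C@@H](NC(=O)c2nc(Cc3ccccc3)n(CCCO)n2)COc2ccccc21` gives 209 nM, and compound 3 `CN1C(=S)[C@@H](NC(=O)c2nc(Cc3ccccc3)n(CCC(F)(F)F)n2)COc2ccccc21` gives 1550 nM. Compound 4 `CN1C(=S)[C@@H](NC(=O)c2nc(Cc3ccccc3)n(C3CCCCC3)n2)COc2ccccc21` differs from compound 1 in one place: cyclohexyl in place of methyl on an aromatic nitrogen. Among the measured compounds shown here, two measured steps bear on this change, since each also enlarges the group on that aromatic nitrogen: an 84-fold higher number from compound 1 to compound 2 (1.92 log units; beyond the scatter) and a 620-fold higher number from compound 1 to compound 3 (2.79 log units; beyond the scatter). The further step a 7.4-fold higher number from compound 2 to compound 3 (0.87 log units; beyond the scatter) shows that the kind of group added matters as well. Because the enlargements an 84-fold higher number from compound 1 to compound 2 (1.92 log units; beyond the scatter) and a 620-fold higher number from compound 1 to compound 3 (2.79 log units; beyond the scatter) both gave much higher numbers, a large step toward a higher number is expected for compound 4 too: a 240-fold higher number from compound 1 to compound 4 (2.38 log units; beyond the scatter). Compound 4 is therefore estimated at 600 nM, within a range from 60 nM to 6000 nM.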

Compound 4, half-maximal effective concentration: 4000 nM
Beside the measured number, compound 4's estimate is 6.7-fold (0.82 log units) below it; low and high end bracket the measured number.
By their numbers in this assay, from the lowest: compound 1; then compound 2; then compound 3; then compound 4.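

In this assay, a cyclohexyl ring on this aromatic nitrogen gives the largest rise seen at this position, a 1600-fold higher number from compound 1 to compound 4 (3.20 log units; beyond the scatter), so none of the larger groups shown comes close to methyl. The ring also sits above both chains, with a 2.6-fold higher number from compound 3 to compound 4 (0.41 log units; beyond the scatter) and a 19-fold higher number from compound 2 to compound 4 (1.28 log units; beyond the scatter), which makes compound 4 the highest of the four. No measurement shown here explains these rises.

The compounds shown leave open how small a change from methyl is enough to raise the number, as an ethyl group or a cyclopropyl ring could show. From the compounds shown here alone, how a chain ending in an amine would behave at this position also stays open.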